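Replacing one ethoxyphenyl arm with a fluorophenyl arm

The compounds below may be only part of what the source reports. "The series", "measured", "known", "first", "only" and "open" are said of these compounds alone.

Compound 1 `Fc1cc(Nc2nc3nonc3nc2Nc2ccc(C(F)(F)F)c(F)c2)ccc1C(F)(F)F` and compound 2 `CCOc1cccc(Nc2nc3nonc3nc2Nc2cccc(OCC)c2)c1` share a core and differ only in their two aryl arms. In an assay on mitochondria from L6 cells (Rattus norvegicus) for activation, with a stated time of 90 min (on this read-out lower numbers stand for an effect already at smaller amounts and higher numbers for an effect only at larger amounts of compound), compound 1 gives 1700 nM, while compound 2 gives 10100 nM, the highest of the two numbers and beyond the scatter from compound 1. Compound 3 `CCOc1cccc(Nc2nc3nonc3nc2Nc2ccccc2F)c1` keeps one arm of compound 2 and changes the other: 2-fluorophenyl in place of 3-ethoxyphenyl on a nitrogen on an aromatic ring. Going by the values given here, with no measured pair to lean on, the fluorine-bearing arms of compound 1 and its 1700 nM suggest a modest downward step. Compound 3 is estimated at 4000 nM, range 1200 nM to 13000 nM, meaning an expected step of a 2.5-fold lower number from compound 2 to compound 3 (0.40 log units; beyond the scatter).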

Compound 3, half-maximal effective concentration: 2200 nM
For compound 3 the middle estimate is 1.8-fold (0.26 log units) above the measured one; low and high end bracket the measured number.
By their numbers in this assay, from the lowest: compounds 1 and 3 (each within the scatter of the next); then compound 2.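

In this assay, going by these compounds alone, the change to 2-fluorophenyl in place of 3-ethoxyphenyl on a nitrogen on an aromatic ring gives a 4.6-fold lower number from compound 2 to compound 3 (0.66 log units; beyond the scatter) and is the first change at a single place in this set. It shows that this one arm alone can move the number beyond the scatter while the other 3-ethoxyphenyl arm stays fixed. Nothing measured here gives a reason for the step. The compounds shown leave open whether the fluorine or the loss of the ethoxy group carries the step. On these data alone, how a plain phenyl or an aminophenyl arm would read at this place also stays open.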